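This account rests on a few compounds, and the source may have more. Where it says the series, first, only, none or still open, it means among the compounds named here.

Only two close relatives have been measured so far in an ADME assay on LLC-PK1 cells (Sus scrofa) for permeability, with a stated time of 3 h, tested at 1 uM; on this read-out lower numbers stand for lower permeability and higher numbers for higher permeability. Compound 1 `O=C(O)CNC(=O)c1c(O)c2c(n(Cc3ccc(C(F)(F)F)cc3)c1=O)CCOC2` gives 4 10^-6 cm/s, and compound 2 `O=C(O)CNC(=O)c1c(O)c2c(n(Cc3ccc(Cl)cc3)c1=O)COC2` gives 2.5 10^-6 cm/s. These two values lie within the usual scatter of repeated measurements, so compound 2 cannot be ranked apart from compound 1. Compound 3 `CC(C)(O)c1ccc(Cn2c3c(c(O)c(C(=O)NCC(=O)O)c2=O)COC3)cc1` keeps the core of compound 2 and changes one group: 1-hydroxy-1-methylethyl in place of chloro on an aromatic carbon. In words, this is 1-hydroxy-1-methylethyl in place of chloro on an aromatic carbon. Among the measured compounds shown here, no measured pair shows a change of this kind, so the expectation rests on the structural change alone and remains uncertain. A small downward step in this assay is expected, close to the edge of the scatter. The estimated change is a 1.7-fold lower number from compound 2 to compound 3 (0.22 log units; within the scatter). For compound 3 the expected value is 1.5 10^-6 cm/s, with an estimated range from 0.7 10^-6 cm/s to 3.2 10^-6 cm/s.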

Compound 3, apparent permeability: < 1.5 10^-6 cm/s
Compound 3: only a limit was reported (the forecaster's own chance of this, stated with the estimate: 10%); the middle value sits exactly at the limit.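

In this assay, 1-hydroxy-1-methylethyl in place of chloro on an aromatic carbon, para to a large group, gives an at least 1.6-fold lower number from compound 2 to compound 3 (0.22 log units; that floor lies within the scatter), the first step read at this position. Compound 3 gives < 1.5 10^-6 cm/s, which is a limit of the assay and not a number. From the compounds shown here alone, the step is therefore only a floor that stays within the scatter, and its true size remains unknown because the reading stops at this edge: the limit of < 1.5 10^-6 cm/s in this assay, at which 1 of the 3 values shown sits.

The compounds shown leave open how isopropyl, which is the entering group without its oxygen, would read at this position, and so whether that oxygen matters to the step. They also leave open how an amine or a carboxylic acid would read in the same place, and whether either would reach a measurable number.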